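A few compounds are considered here, and "the series" means these few. Any claim that something is new, unique, unknown or untested is made for them only; others in the source may bear on it.

Measured compounds:
compound 1 `COC(OC)C1=C(C(=O)OC/C=C/c2ccccc2)C(c2cccc(Cl)c2)C(C(=O)O)=C(C)N1`, 8100 nM
compound 2 `COC(OC)C1=C(C(=O)OC/C=C/c2ccc(F)cc2)C(c2cccc(Cl)c2)C(C(=O)O)=C(C)N1`, 2000 nM

In an assay on thoracic aorta for inhibition of Voltage-gated L-type calcium channel (Rattus norvegicus) (on this read-out higher numbers stand for weaker inhibition and lower numbers for stronger inhibition), compound 1 gives 8100 nM, the higher of the two numbers; the measured set shows a 4.1-fold lower number from compound 1 to compound 2 (0.61 log units; beyond the scatter). Compound 3 `COC(OC)C1=C(C(=O)OC/C=C/c2ccc(C(F)(F)F)cc2)C(c2cccc(Cl)c2)C(C(=O)O)=C(C)N1` differs from compound 1 by trifluoromethyl in place of hydrogen on an aromatic carbon. Within the data shown here, only one measured step bears on this change, the one from compound 1 to compound 2, which was modest and involved fluoro rather than trifluoromethyl. A step of similar direction, though less certain, is expected here. Compound 3 is therefore estimated to show a 2.7-fold lower number from compound 1 to compound 3 (0.43 log units; beyond the scatter), with an expected value of 3000 nM and a range from 800 nM to 12000 nM.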

Compound 3, half-maximal inhibitory concentration: 3200 nM
Beside the measured number, compound 3's estimate is 1.1-fold (0.03 log units) below it; the measured number falls inside the stated range.
By their numbers in this assay, from the lowest: compounds 2 and 3 (each within the scatter of the next); then compound 1.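

In this assay trifluoromethyl on the aromatic carbon para to a large group gives a 2.5-fold lower number from compound 1 to compound 3 (0.40 log units; beyond the scatter) and so shows that the lower number seen with fluoro at this position is not unique to fluoro. Trifluoromethyl in place of fluoro gives a 1.6-fold higher number from compound 2 to compound 3 (0.20 log units; within the scatter) and so leaves the two groups unseparated at this position in this assay. Nothing at hand explains how either group lowers the number. From the compounds shown here alone, whether a methoxy group or an amine on this carbon would move the number the same way stays open. So does the effect of fluoro or trifluoromethyl on another carbon of the ring.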